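Methyl for nitrile on the phenylpiperazine of compound 3

The source may hold more compounds than are shown below. What is called first, only, known or untested is meant among the compounds shown, and "the series" means these compounds.

Compound 3 `N#Cc1ccccc1N1CCN(CC(O)Cn2nc(-c3ccc(I)cc3)c3c2CCN(C(N)=O)C3)CC1` gives 50 nM in an assay on isolated protein for inhibition of cathepsin S (Homo sapiens) (on this read-out higher numbers stand for weaker inhibition and lower numbers for stronger inhibition), the lowest of the three numbers. Within the data shown here, compound 2 `CC(=O)N1CCc2c(c(-c3ccc(I)cc3)nn2CC(O)CN2CCN(c3ccccc3C#N)CC2)C1` gives 120 nM, and the step of a 2.4-fold lower number from compound 2 to compound 3 (0.38 log units; beyond the scatter) is the only single change measured. Compound 1 `COc1ccccc1N1CCN(CCCCn2nc(-c3ccc(Cl)cc3)c3c2CCN(C(C)=O)C3)CC1` gives 9500 nM, but differs from compound 3 in several places at once. Compound 4 `Cc1ccccc1N1CCN(CC(O)Cn2nc(-c3ccc(I)cc3)c3c2CCN(C(N)=O)C3)CC1` carries the change (methyl in place of cyano on an aromatic carbon). Among the measured compounds shown here, no measured step covers this change, so the expectation rests on the general picture that compound 3 sits at the strong end and that changes on this ring are untested. Compound 4 is expected to give 150 nM, within 40 nM to 600 nM, which means an estimated step of a 3.0-fold higher number from compound 3 to compound 4 (0.48 log units; beyond the scatter) toward a somewhat higher number.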

Compound 4, half-maximal inhibitory concentration: 14000 nM
For compound 4 the middle estimate is 93-fold (1.97 log units) below the measured one, outside the stated range (above it).
By their numbers in this assay, from the lowest: compound 3; then compound 2; then compounds 1 and 4 (each within the scatter of the next).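

On this aromatic carbon, ortho to a large group, going from 2-cyanophenyl to 2-methylphenyl gives a 280-fold higher number from compound 3 to compound 4 (2.45 log units; beyond the scatter) in this assay, a large step that far exceeds the only other single change shown, a 2.4-fold lower number from compound 2 to compound 3 (0.38 log units; beyond the scatter). Inhibition on this series therefore depends heavily on which group sits at this position, and here methyl does not stand in for the nitrile. The data at hand offer no explanation for a step of this size. On these data alone, whether a fluorine atom or a carboxylic acid on this carbon would keep the low number of compound 3 remains open.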